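The source may report more compounds than this note shows. Statements on the series, on what has been measured and on what is new or still open speak of the compounds shown alone.

Measured in a functional assay on FM3A cells (Mus musculus) for antiproliferative activity, with a stated time of 48 h; on this read-out lower numbers stand for stronger inhibition and higher numbers for weaker inhibition:
- Compound 1 `C=C(Br)C(=O)Nc1ccc(C(=O)/C=C/c2ccc(OC)c(OC)c2)cc1`: 1200 nM
- Compound 2 `C=C(Br)C(=O)Nc1ccc(C(=O)/C=C/c2cc(OC)cc(OC)c2)cc1`: 2000 nM

Compound 2, at 2000 nM, cannot be told apart from compound 1, at 1200 nM: the two values lie within the usual scatter of repeated measurements. Compound 3 `C=C(Br)C(=O)Nc1ccc(C(=O)/C=C/c2cc(OC)c(OC)c(OC)c2)cc1` is compound 2 with a single change, methoxy in place of hydrogen on an aromatic carbon. Among the compounds with values here, no measured pair here shows what such a change does, so any expectation is a judgement and needs a wide range. A modest move towards stronger inhibition is expected in this assay, though a result close to compound 2 would remain possible. The expected change is a 2.9-fold lower number from compound 2 to compound 3 (0.46 log units; beyond the scatter), an estimate only. For compound 3 the estimated value is 700 nM, with an expected range of 200 nM to 2500 nM.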

Compound 3, half-maximal inhibitory concentration: 1800 nM
Beside the measured number, compound 3's estimate is 2.6-fold (0.41 log units) below it, and the stated range covers the measured number.
By their numbers in this assay, from the lowest: compounds 1, 3 and 2 (each within the scatter of the next).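

In this assay, placing a methoxy group ortho to two methoxy groups gives a 1.1-fold lower number from compound 2 to compound 3 (0.05 log units; within the scatter) and so leaves no difference that can be told from the noise of the measurement: at this position, the added group can be present without any detectable shift in the read-out. The comparison with the other dimethoxy compound agrees, showing a 1.5-fold higher number from compound 1 to compound 3 (0.18 log units; within the scatter) and placing all three compounds within the same band of uncertainty. No measurement here offers an explanation for this result. Going by these compounds, what remains open is whether a different group at this position, such as an amine or a carboxylic acid, would move the number beyond the scatter. A longer chain, such as butoxy, could also show whether this position accepts more bulk than a methoxy group.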